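The compounds below may be only part of what the source reports. "The series", "measured", "known", "first", "only" and "open" are said of these compounds alone.

Working notes on the series. Compound 1 `COC1Cc2sccc2C2(CCNCC2)O1` carries the shared core with a free amine nitrogen in the ring; in an assay on membranes from brain for displacement of a labelled ligand from Sigma non-opioid intracellular receptor 1 (Cavia porcellus) (a higher number here means a weaker inhibitor, a lower number a stronger inhibitor), compound 1 gives 602 nM. Compound 2 `COC1Cc2sccc2C2(CCN(Cc3cccs3)CC2)O1` adds a (thiophen-2-yl)methyl group to that nitrogen, and in this assay compound 2 gives 2 nM. Within the data shown here, the single measured step is a 300-fold lower number from compound 1 to compound 2 (2.48 log units; beyond the scatter), so compound 2 stands at the lowest of the two numbers, with compound 1 as its only neighbour.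

Compound 3 `COC1Cc2sccc2C2(CCN(CC=C(C)C)CC2)O1` differs from compound 2 by 2-methylprop-1-en-1-yl in place of thiophen-2-yl on a saturated chain carbon bound to an amine nitrogen in a ring. Among the measured compounds shown here, no measured step swaps one nitrogen substituent for another; the only step that bears on this position, a 300-fold lower number from compound 1 to compound 2 (2.48 log units; beyond the scatter), shows that filling the nitrogen is what moves the number most, and compound 3 keeps the nitrogen filled. A modest rise is therefore expected, a 3.0-fold higher number from compound 2 to compound 3 (0.48 log units; beyond the scatter), well short of the gap to compound 1. For compound 3 in this assay the expected value is 6 nM, within a range of 1.5 nM to 25 nM.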

Compound 3, inhibition constant: 1 nM
Estimate against measurement, compound 3: 6.0-fold (0.78 log units) above; measured number outside the range, below it.
By their numbers in this assay, from the lowest: compounds 3 and 2 (each within the scatter of the next); then compound 1.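

In this assay, 2-methylprop-1-en-1-yl in place of thiophen-2-yl on a saturated chain carbon bound to an amine nitrogen in a ring gives a 2.0-fold lower number from compound 2 to compound 3 (0.30 log units; within the scatter) and so shows that, in this pair, the aromatic ring and its sulfur are not needed to keep the number this low. The large step on filling the nitrogen is also no longer tied to a single group: 3-methylbut-2-en-1-yl in place of hydrogen gives a 600-fold lower number from compound 1 to compound 3 (2.78 log units; beyond the scatter) and stands alongside a 300-fold lower number from compound 1 to compound 2 (2.48 log units; beyond the scatter) as a second example. Nothing available gives a reason for either result.

As far as these compounds go, whether the double bond matters remains open, and a saturated 3-methylbutyl chain would address that. Also open, from the compounds shown here alone, is how a phenyl ring or a much longer chain would fare on this nitrogen.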